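The source may hold more compounds than are shown below. What is called first, only, known or untested is meant among the compounds shown, and "the series" means these compounds.

In a toxicity assay on cells (Erythrocyte, Mus musculus) for activation, read by spectrophotometry and hemolysis, with a stated time of 30 min (a higher number here means that more compound is needed for the effect, a lower number that less compound is needed), compound 2 (`Clc1ccc(/C=N/Nc2nc3ccccc3s2)cc1`) gives > 200 ug/mL as a limit and not a number. Compound 1 (`Oc1ccc(/C=N/Nc2nc3ccccc3s2)cc1O`) gives > 200 ug/mL as a limit too. Compound 3 (`Clc1ccc(/C=N/Nc2nc3ccccc3s2)c(Cl)c1`) gives > 200 ug/mL as a limit too. Compound 4 (`Brc1ccc(/C=N/Nc2nc3ccccc3s2)cc1`) follows from compound 2 by bromo in place of chloro on an aromatic carbon on an aromatic carbon, para to a large group. For the measured compounds named here, the only measured step is a step that the two limits leave unreadable from compound 2 to compound 3 and offers no size to carry over to this change. For compound 4, no step beyond the scatter is expected in this assay because of the limit of > 200 ug/mL in this assay, at which 3 of the 3 values shown sit, and another limit is the likely report. The expected step is a step that the limit leaves unreadable from compound 2 to compound 4 and remains an estimate. The estimate for compound 4 is 250 ug/mL with a range from 150 ug/mL to 600 ug/mL in this assay for the coming measurement.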

Compound 4, half-maximal effective concentration: > 200 ug/mL
Compound 4: no number, only a limit; the forecaster's own chance of this, stated with the estimate: 90%; the middle value is on the limit's open side.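

In this assay compound 4 gives > 200 ug/mL, a limit and not a number, and the step from compound 2 to compound 4 cannot be read. The compounds shown leave open what concentration, if any, gives half-maximal hemolysis for any of them.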